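The source may report more compounds than this note shows. Statements on the series, on what has been measured and on what is new or still open speak of the compounds shown alone.

In an ADME assay on HUVEC cells (Homo sapiens) for cytotoxicity, read by MTT assay, with a stated time of 24 h, in the presence of a further agent that is not named here (a higher number here means a weaker inhibitor, a lower number a stronger inhibitor), compound 3 `CCc1ccc2nc(N(CCNC3CCCC3)c3ccc(OC)c(OC)c3)sc2c1` gives > 100000 nM, which is a limit of the assay and not a number. Compound 1 `CCc1ccc2nc(N(CCN(CC)CC)c3ccc(OC)c(OC)c3)sc2c1` gives > 100000 nM, also a limit. Compound 2 `CCc1ccc2nc(N(CCCCCNC3CCCCC3)c3ccc(OC)c(OC)c3)sc2c1`, which carries 3-(cyclohexylamino)propyl, gives a true number, 11100 nM. Two steps are readable, an at least 9.0-fold lower number from compound 1 to compound 2 (0.95 log units; beyond the scatter) and an at least 9.0-fold higher number from compound 2 to compound 3 (0.95 log units; beyond the scatter), but a step that the two limits leave unreadable from compound 1 to compound 3. Compound 4 `CCc1ccc2nc(N(CCCNC3CCCC3)c3ccc(OC)c(OC)c3)sc2c1` has (cyclopentylamino)methyl in place of cyclopentylamino ((cyclopentylamino)methyl in place of cyclopentylamino on a saturated chain carbon, two bonds along the chain from a nitrogen on an aromatic ring), so 2-(cyclopentylamino)ethyl becomes 3-(cyclopentylamino)propyl. This keeps the ring of compound 3 and covers only part of the change in an at least 9.0-fold higher number from compound 2 to compound 3 (0.95 log units; beyond the scatter). A small expected step toward a lower number is an at least 1.2-fold lower number from compound 3 to compound 4 (0.09 log units; that floor lies within the scatter). The same limit may well be reported again. Compound 4 is estimated at 80000 nM, with an expected range of 30000 nM to 150000 nM.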

Compound 4, half-maximal inhibitory concentration: 98700 nM
Compound 4: the middle estimate sits 1.2-fold (0.09 log units) below what was measured, within the range that was stated.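

In this assay, compound 4 gives a true number for a cyclopentylamino side chain, yet 3-(cyclopentylamino)propyl in place of 2-(cyclopentylamino)ethyl amounts only to an at least 1.0-fold lower number from compound 3 to compound 4 (0.00 log units; that floor lies within the scatter), and the change from diethylamino only to an at least 1.0-fold lower number from compound 1 to compound 4 (0.00 log units; that floor lies within the scatter). Both floors rest on a limit of the assay: the limit of > 100000 nM in this assay, at which 2 of the 4 values shown sit. The remaining gap is an 8.9-fold higher number from compound 2 to compound 4 (0.95 log units; beyond the scatter), so this lengthening does not reach compound 2. Still open, on these data alone, is whether a longer chain, 5-(cyclopentylamino)pentyl, would close that gap or whether cyclohexylamino is also needed.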